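The source may hold more compounds than are shown below. What is called first, only, known or untested is meant among the compounds shown, and "the series" means these compounds.

In a functional assay on MC-38 cells (Mus musculus) for antiproliferative activity, read by CCK-8 assay, with a stated time of 48 h (on this read-out higher numbers stand for weaker inhibition and lower numbers for stronger inhibition), compound 1 (`COc1ccc(/C=C\c2cc(OC)c(OC)c(OC)c2)cc1OCc1ccc(CNC(C)(C)C(=O)O)cc1`) gives > 10000 nM, which is a limit and not a number. Compound 2 (`COc1ccc(/C=C\c2cc(OC)c(OC)c(OC)c2)cc1OCc1ccc(CN2C[C@H](O)C[C@@H]2C(=O)O)cc1`) gives > 10000 nM, again a limit. Compound 3 (`COc1ccc(/C=C\c2cc(OC)c(OC)c(OC)c2)cc1OCc1ccc(CN2CC(C(=O)O)C2)cc1`) gives > 10000 nM, also a limit, so it has no readable place within the series. The whole set sits at one reading: the limit of > 10000 nM in this assay, at which 3 of the 3 values shown sit.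

Compound 4 (`COc1ccc(/C=C\c2cc(OC)c(OC)c(OC)c2)cc1OCc1ccc(CN2CC[C@@H](C(=O)O)C2)cc1`) carries 3-carboxypyrrolidin-1-yl in place of 3-carboxyazetidin-1-yl on a saturated chain carbon bound to an aromatic carbon.

The steps bearing on this change are a step that the two limits leave unreadable from compound 2 to compound 3 and a step that the two limits leave unreadable from compound 1 to compound 3, with a step that the two limits leave unreadable from compound 1 to compound 2 as the remaining comparison. None of them has a readable size, so they offer no measured basis for a shift. No step beyond the usual scatter is therefore expected in this assay, and no direction can be assigned. The expected change is a step that the limit leaves unreadable from compound 3 to compound 4. The estimate for compound 4 is 15000 nM, with an expected range of 5000 nM to 40000 nM, and the assay will most likely report only a limit again.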

Compound 4, half-maximal inhibitory concentration: 6300 nM
The estimate for compound 4 lay 2.4-fold (0.38 log units) above the measured number; the measured number falls inside the stated range.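

At the saturated chain carbon bound to an aromatic carbon, 3-carboxypyrrolidin-1-yl gives the only readable number of the four groups shown, with compound 4 at 6300 nM in this assay and the steps among compound 1, compound 2 and compound 3 unreadable. The steps into compound 4 are floors only, with an at least 1.5-fold lower number from compound 3 to compound 4 (0.20 log units; that floor lies within the scatter) and an at least 1.5-fold lower number from compound 2 to compound 4 (0.20 log units; that floor lies within the scatter) and an at least 1.5-fold lower number from compound 1 to compound 4 (0.20 log units; that floor lies within the scatter) all leaving open whether the change exceeds the scatter. Compound 4 is therefore the series' single measured reference point, and the other entries remain limits: the limit of > 10000 nM in this assay, at which 3 of the 4 values shown sit.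

Going by these compounds, whether the carboxylic acid is needed remains open, since neither its methyl ester nor a primary amide appears at this place. Also open, on these data alone, are the six-membered 3-carboxypiperidin-1-yl group and the opposite configuration at the defined stereocentre of 3-carboxypyrrolidin-1-yl.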